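Swapping the sulfonyl aryl group in a piperidinyl-piperidine series

The compounds below may be only part of what the source reports. "The series", "measured", "known", "first", "only" and "open" are said of these compounds alone.

Measured compounds:
compound 1 `Cc1noc(C)c1S(=O)(=O)N1CCC(N2CCC(C)CC2)CC1`: > 5000 nM
compound 2 `CC1CCN(C2CCN(S(=O)(=O)c3cccc(-c4ccc(F)cc4)c3)CC2)CC1`: 12 nM
compound 3 `Cc1ccc(-c2cccc(S(=O)(=O)N3CCC(N4CCC(C)CC4)CC3)c2)cc1`: 11 nM

All three share a core of two linked piperidine rings carrying a sulfonyl group, and were tested in a functional assay on DLD-1 cells (Homo sapiens) for antiproliferative activity, read by CellTiter-Glo, with a stated time of 72 h; on this read-out higher numbers stand for weaker inhibition and lower numbers for stronger inhibition. Compound 1 carries a 3,5-dimethyl-1,2-oxazol-4-yl group on the sulfonyl sulfur, and in this assay compound 1 is reported only as a limit, > 5000 nM, as noted in the limit of > 5000 nM in this assay, at which 1 of the 3 values shown sits. Compounds 2 and 3 instead carry a phenyl ring bearing a second aromatic ring, and both give low numbers; the step of a 1.1-fold lower number from compound 2 to compound 3 (0.04 log units; within the scatter) shows that exchanging the group on the distal ring leaves the number where it was.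

Compound 4 `CC1CCN(C2CCN(S(=O)(=O)c3ccc(Cl)c(Cl)c3)CC2)CC1` is not yet measured. Its change from compound 1 is 3,4-dichlorophenyl in place of 3,5-dimethyl-1,2-oxazol-4-yl on a sulfonyl sulfur. No measured step covers this change: the only step shown concerns a substituent on a second ring that compound 4 does not have. What the values of compounds 2 and 3 show is that an aromatic carbon ring on the sulfonyl sulfur is compatible with strong inhibition, whereas compound 1 with its five-membered ring reaches only the limit. Compound 4 is therefore expected to move toward a measurable number, giving an estimated step of an at least 20-fold lower number from compound 1 to compound 4 (1.30 log units; beyond the scatter). The estimate for compound 4 is 250 nM, within a range from 40 nM to 2500 nM.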

Compound 4, half-maximal inhibitory concentration: 2.9 nM
Compound 4: the middle estimate sits 86-fold (1.94 log units) above what was measured; measured number outside the range, below it.
By their numbers in this assay, from the lowest: compound 4; then compounds 3 and 2 (each within the scatter of the next). At a limit, above all of these: compound 1.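

Only the group on the sulfonyl sulfur differs between these two compounds, and in this assay that single exchange gives an at least 1700-fold lower number from compound 1 to compound 4 (3.23 log units; beyond the scatter), so in this pair the group at this position separates a limit from a very low number. The true size of this step remains unknown because the result for compound 1 is a limit rather than a number: the limit of > 5000 nM in this assay, at which 1 of the 4 values shown sits.

Compound 4 has a single aromatic ring on the sulfonyl sulfur, without the second aromatic ring found in compounds 2 and 3, and compound 4 still gives 2.9 nM, so that second ring is not needed for a low number.

The exchange changes several things at once, since a five-membered ring with nitrogen and oxygen gives way to a six-membered ring of carbon only and two methyl groups give way to two chlorines, and the compounds shown cannot say which of these matters. As far as these compounds go, it also remains open whether a phenyl ring with one chlorine or none, or with an amine or a carboxylic acid in place of the chlorines, would keep the number this low.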